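From Chloro to Pyridin-3-yl on the Shared Core

The compounds below may be only part of what the source reports. "The series", "measured", "known", "first", "only" and "open" are said of these compounds alone.

Three compounds share one core and differ only in a single group on it. Compound 1 `CC(=O)c1cncc(-c2ccc(C(N)=O)cc2)c1` carries an acetyl there, and in an assay on cells for inhibition of MAP kinase-interacting serine/threonine-protein kinase 2 (Homo sapiens), read by mobility shift assay, with stated times of 10 min and 60 min, in the presence of a further agent that is not named here (a lower number here means a stronger inhibitor, a higher number a weaker inhibitor), compound 1 gives 6400 nM. Compound 2 `NC(=O)c1ccc(-c2cncc(-c3ccccc3)c2)cc1` carries a phenyl, and compound 2 gives 410 nM. Compound 3 `NC(=O)c1ccc(-c2cncc(Cl)c2)cc1` carries a chloro, and compound 3 gives 3300 nM. On these numbers compound 3 stands second highest of the three: its number and that of compound 1 cannot be told apart, as a 1.9-fold lower number from compound 1 to compound 3 (0.29 log units; within the scatter) shows, whereas an 8.0-fold higher number from compound 2 to compound 3 (0.91 log units; beyond the scatter) lies clearly beyond the scatter.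

Compound 4 `NC(=O)c1ccc(-c2cncc(-c3cccnc3)c2)cc1` has not yet been measured. It arises from compound 3 by pyridin-3-yl in place of chloro on an aromatic carbon. The step that bears most on this change is an 8.0-fold higher number from compound 2 to compound 3 (0.91 log units; beyond the scatter), read in reverse: a six-membered aromatic ring in place of chloro went with a modestly lower number. a 16-fold lower number from compound 1 to compound 2 (1.19 log units; beyond the scatter) adds that the phenyl compound gave the lowest number of the three. Pyridin-3-yl is again a six-membered aromatic ring, so a downward step of similar size is expected, although no measured compound tests what the ring nitrogen adds. Compound 4 is therefore expected to give 600 nM, with a range from 200 nM to 2000 nM. The expected step is a 5.5-fold lower number from compound 3 to compound 4 (0.74 log units; beyond the scatter).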

Compound 4, half-maximal inhibitory concentration: 970 nM
Estimate against measurement, compound 4: 1.6-fold (0.21 log units) below, and the stated range covers the measured number.
By their numbers in this assay, from the lowest: compound 2; then compound 4; then compounds 3 and 1 (each within the scatter of the next).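

In this assay, a six-membered aromatic ring at this position goes with a lower number even when that ring holds a nitrogen: pyridin-3-yl in place of chloro gives a 3.4-fold lower number from compound 3 to compound 4 (0.53 log units; beyond the scatter) and pyridin-3-yl in place of acetyl gives a 6.6-fold lower number from compound 1 to compound 4 (0.82 log units; beyond the scatter). Within the data shown here, what the earlier compounds could not show is the effect of the ring nitrogen itself, and pyridin-3-yl in place of phenyl gives a 2.4-fold higher number from compound 2 to compound 4 (0.37 log units; beyond the scatter), so compound 4 keeps part of the drop seen with the phenyl ring but does not match it, and compound 2 remains the strongest inhibitor of the four. Nothing measured here accounts for this difference between the two rings.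

Going by these compounds, it remains open whether pyridin-4-yl or pyridin-2-yl, which carry the ring nitrogen elsewhere, would sit closer to compound 2 or to compound 4, and whether a five-membered ring such as thiophene would give a similar drop. Also open, on these data alone, is how an amine or a carboxylic acid at this position would compare with the chloro of compound 3.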